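Chloro to Methyl: Estimating a Fourth Cytotoxic Compound

The source may report more compounds than this note shows. Statements on the series, on what has been measured and on what is new or still open speak of the compounds shown alone.

Measured so far:
compound 1 `Cc1ccc2c(c1)CCCN2c1nc(Cl)nc2ccccc12`: 57 nM
compound 2 `Cc1ccc2c(c1)CCCN2c1nc(C)nc2ccccc12`: 187 nM
compound 3 `COc1ccc2c(c1)CCCCN2c1nc(Cl)nc2ccccc12`: 165 nM

All three were tested in a functional assay on DU-145 cells (Homo sapiens) for cytotoxicity, read by sulforhodamine B assay; on this read-out lower numbers stand for stronger inhibition of growth and higher numbers for weaker inhibition of growth. Compound 1 and compound 2 share one core and differ in a single place, (methyl in place of chloro on an aromatic carbon). This change gave a 3.3-fold higher number from compound 1 to compound 2 (0.52 log units; beyond the scatter), a modest weakening of growth inhibition. Compound 3 sits on a different core; how the core of compound 1 and the core of compound 3 differ is not broken down here. In this assay compound 3 and compound 2 give values within the usual scatter of each other, while compound 1 gives the lowest number of the three.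

Compound 4, `COc1ccc2c(c1)CCCCN2c1nc(C)nc2ccccc12`, has not yet been measured. It differs from compound 3 by methyl in place of chloro on an aromatic carbon, the same change at the same kind of place as that made from compound 1 to compound 2. Because that earlier change gave a 3.3-fold higher number from compound 1 to compound 2 (0.52 log units; beyond the scatter), a comparable weakening is expected here, with an expected step of a 3.0-fold higher number from compound 3 to compound 4 (0.48 log units; beyond the scatter). Compound 4 is therefore estimated at 500 nM, likely falling between 220 nM and 1200 nM.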

Compound 4, concentration for 50% growth inhibition: 18 nM
The estimate for compound 4 lay 28-fold (1.44 log units) above the measured number; the measured number lies below the stated range.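

In this assay, putting methyl in place of chloro on the aromatic carbon between two ring nitrogen atoms gave a 9.2-fold lower number from compound 3 to compound 4 (0.96 log units; beyond the scatter), a stronger inhibition of growth on this core rather than the weaker one seen before. Set beside the earlier step, the same change moved the number in opposite directions on the two cores, and the two steps clearly differ: the same change on two cores in this assay, a 3.3-fold higher number (0.52 log units; beyond the scatter) from compound 1 to compound 2 and a 9.2-fold lower number (0.96 log units; beyond the scatter) from compound 3 to compound 4, 30-fold (1.48 log units) apart, beyond the scatter of two such steps. For the compounds shown here, this shows that the effect of this change did not carry over from one core to the other, but with only two pairs it does not show why, and it offers no rule for any further core.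

The compounds shown do not separate the differences between the core of compound 1 and the core of compound 3, which leaves open which of them goes with the change of direction. Also open, as far as these compounds go, is how other groups at this place, such as an amine or a nitrile, would behave on either core.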